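This account rests on a few compounds, and the source may have more. Where it says the series, first, only, none or still open, it means among the compounds named here.

Measured so far in a functional assay on DU-145 cells (Homo sapiens) for inhibition, read by trypan blue exclusion, with a stated time of 96 h; a higher number here means a weaker inhibitor of growth, a lower number a stronger inhibitor of growth: compound 1 `O=C(O)c1ccc(/C=C(/SCc2ccc(Cl)cc2)C(=O)c2ccc(C(=O)O)cc2)cc1` gives > 100000 nM, which is a limit of the assay and not a number. Compound 2 `Cc1ccc(CS/C(=C/c2ccc(F)c([N+](=O)[O-])c2)C(=O)c2ccc(Cl)c([N+](=O)[O-])c2)cc1` gives 1000 nM. Compound 3 `O=C(O)c1ccc(C(=O)/C(=C\c2ccc(F)c([N+](=O)[O-])c2)SCc2ccc(Cl)cc2)cc1` gives 50000 nM.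

Compound 2 holds the lowest number of the two numbers given, and compound 3 lies well above it. The cores of compound 2 and compound 3 differ, and the difference between the two cores is not broken down here. From compound 3 to compound 1 the change is 4-carboxyphenyl in place of 4-fluoro-3-nitrophenyl on a double-bonded chain carbon bound to a double-bonded chain carbon, giving an at least 2.0-fold higher number from compound 3 to compound 1 (0.30 log units; that floor lies within the scatter). Because compound 1 sits at the assay limit (the limit of > 100000 nM in this assay, at which 1 of the 3 values shown sits), the full size of that step is open.

Compound 4 `Cc1ccc(CS/C(=C/c2ccc(C(=O)O)cc2)C(=O)c2ccc(Cl)c([N+](=O)[O-])c2)cc1` is not yet measured. It arises from compound 2 by the same change, (4-carboxyphenyl in place of 4-fluoro-3-nitrophenyl on a double-bonded chain carbon bound to a double-bonded chain carbon). In this assay a step of a 10-fold higher number from compound 2 to compound 4 (1.00 log units; beyond the scatter) is expected, placed beside an at least 2.0-fold higher number from compound 3 to compound 1 (0.30 log units; that floor lies within the scatter), resting on that single earlier example and on the low starting point of compound 2 at 1000 nM. Compound 4 is estimated at 10000 nM, expected between 2000 nM and 100000 nM.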

Compound 4, concentration for 50% growth inhibition: 10000 nM
Estimate against measurement, compound 4: no gap at the digits printed, within the range that was stated.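

In this assay, 4-carboxyphenyl in place of 4-fluoro-3-nitrophenyl gives a clear step on the core of compound 2, with a 10-fold higher number from compound 2 to compound 4 (1.00 log units; beyond the scatter). Compound 1 gives > 100000 nM, a limit of the assay and not a number, so only a floor is available for the same change on its core. Whether the change carries from one core to the other at the same size is therefore not shown: the same change on two cores in this assay, an at least 2.0-fold higher number (0.30 log units; that floor lies within the scatter) from compound 3 to compound 1 and a 10-fold higher number (1.00 log units; beyond the scatter) from compound 2 to compound 4; the limit leaves it open whether they differ.

Still open, on these data alone, is whether an ester or an amide in place of the carboxylic acid of 4-carboxyphenyl would give a number nearer that of compound 2 or that of compound 4. Two cores also cannot show how the change behaves across the wider series.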